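The source may report more compounds than this note shows. Statements on the series, on what has been measured and on what is new or still open speak of the compounds shown alone.

Working notes on the series.

The parent, compound 1 `c1cncc(N2CC[C@@H]3CN[C@@H]3C2)c1`, gives in a functional assay on HEK293 cells for agonist activity at Neuronal acetylcholine receptor; alpha3/beta4 (Homo sapiens), read by FLIPR (on this read-out lower numbers stand for an effect already at smaller amounts and higher numbers for an effect only at larger amounts of compound), a value of 260 nM. Within the data shown here, the bromo analogue, compound 2 `Brc1cncc(N2CC[C@@H]3CN[C@@H]3C2)c1`, gives 950 nM; the step of a 3.7-fold higher number from compound 1 to compound 2 (0.56 log units; beyond the scatter) is the only single-point change measured so far. Compound 3 `N#Cc1cncc(N2CC[C@H]3CN[C@H]3C2)c1`, the nitrile drawn with the inverted configuration, gives 1000 nM and stands highest of the three numbers, close to compound 2 and well apart from compound 1.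

Compound 4 `N#Cc1cncc(N2CC[C@@H]3CN[C@@H]3C2)c1` is the next step: the two compounds have the same atoms and bonds and differ only in configuration as drawn: 2 of 2 stereo elements differ (all stereocentres are inverted: mirror images); a stereocentre at a saturated ring carbon is drawn S in compound 3 and R in compound 4; a stereocentre at a saturated ring carbon is drawn R in compound 3 and S in compound 4. Compound 4 thus carries the configuration in which compounds 1 and 2 are drawn. Among the measured compounds shown here, no measured step in this set bears on an inversion of configuration, so the size of the effect has no precedent here; the bromo step from compound 1 to compound 2 concerns a substituent, not the ring carbons. The expectation rests only on the range spanned by compounds 1, 2 and 3, with wide uncertainty in either direction. For compound 4 the expected value is 600 nM, from 100 nM to 4000 nM, meaning an estimated step of a 1.7-fold lower number from compound 3 to compound 4 (0.22 log units; within the scatter).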

Compound 4, half-maximal effective concentration: 490 nM
Compound 4: middle estimate off by 1.2-fold (0.09 log units), on the high side; low and high end bracket the measured number.
By their numbers in this assay, from the lowest: compounds 1, 4, 2 and 3 (each within the scatter of the next, the first and the last beyond it).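

In this assay the step of a 2.0-fold lower number from compound 3 to compound 4 (0.31 log units; beyond the scatter) is the first reading on configuration in the series; it is modest, and it can be assigned to configuration alone: the fact that compounds 3 and 4 differ only in the configuration as drawn

With the configuration of compounds 1 and 2 in place, the nitrile cannot be told apart from either neighbour, since both a 1.9-fold lower number from compound 2 to compound 4 (0.29 log units; within the scatter) and a 1.9-fold higher number from compound 1 to compound 4 (0.28 log units; within the scatter) lie within the scatter. Hydrogen and bromo do separate from each other, with a 3.7-fold higher number from compound 1 to compound 2 (0.56 log units; beyond the scatter) beyond the scatter, and the nitrile in compound 4 sits between them without a readable difference from either.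

Open, going by these compounds, is whether inverting both stereocentres would give a step of similar size with hydrogen or bromo in place of the nitrile. Also open, on these data alone, is how an amine or a carboxylic acid on the same aromatic carbon would read.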